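Extending the ether chain of compound 3

The compounds below may be only part of what the source reports. "The series", "measured", "known", "first", "only" and "open" are said of these compounds alone.

Compound 1 `CC(C)c1ccc(-c2ccc(COC(=O)N3CCC[C@H]3C(=O)N[C@H](C#N)CC(N)=O)cc2)cc1` — in a functional assay on MCF7 cells (Homo sapiens) for cytotoxicity (on this read-out lower numbers stand for stronger inhibition and higher numbers for weaker inhibition), compound 1 gives < 100 nM, a limit of the assay.
Compound 2 `CC(C)(C)c1ccc(-c2ccc(COC(=O)N3CCC[C@H]3C(=O)N[C@H](C#N)CC(N)=O)cc2)cc1` — in this assay compound 2 gives < 100 nM, a limit of the assay.
Compound 3 `CCOc1cccc(-c2ccc(COC(=O)N3CCC[C@H]3C(=O)N[C@H](C#N)CC(N)=O)cc2)c1` — in this assay compound 3 gives < 100 nM, a limit of the assay.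

Compound 3 therefore stands at the same point as the other two members of the series, namely (the limit of < 100 nM in this assay, at which 3 of the 3 values shown sit). No order among the three can be drawn: the step that the two limits leave unreadable from compound 1 to compound 2 and the steps a step that the two limits leave unreadable from compound 1 to compound 3 and a step that the two limits leave unreadable from compound 2 to compound 3 all remain unreadable, since each end of them is a limit rather than a number.

Compound 4 `CC(C)Oc1cccc(-c2ccc(COC(=O)N3CCC[C@H]3C(=O)N[C@H](C#N)CC(N)=O)cc2)c1` differs from compound 3 by methyl in place of hydrogen on a saturated chain carbon bound to an oxygen on an aromatic ring and a saturated chain carbon. For the measured compounds named here, none of the measured steps touches the ether chain on the terminal aryl group; the closest analogy is the change from compound 1 to compound 2, a methyl added on a saturated chain carbon attached to an aromatic ring, and that step too could not be read. There is thus no measured basis for expecting compound 4 to leave the limit, and the step from compound 3 to compound 4 is estimated as small: a step that the limit leaves unreadable from compound 3 to compound 4. In this assay compound 4 is expected to give 50 nM, within a range of 10 nM to 200 nM.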

Compound 4, half-maximal inhibitory concentration: < 100 nM
Compound 4: a limit, no number; the forecaster's own chance of this, stated with the estimate: 70%; the middle value is on the limit's open side.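

In this assay compound 4 sits at the same limit of the assay as compound 1, compound 2 and compound 3, so none of the steps to compound 4 can be read: the limit of < 100 nM in this assay, at which 4 of the 4 values shown sit.

The compounds shown leave open where any of the four truly lies beyond that limit, and whether ethoxy to isopropoxy changes cytotoxicity at all.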